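From 4-fluorobenzyl to 2-chlorobenzyl on a shared core

The source may report more compounds than this note shows. Statements on the series, on what has been measured and on what is new or still open speak of the compounds shown alone.

Measured so far in a functional assay on a cell-free system (plasma, Oryctolagus cuniculus) for inhibition, with stated times of 5 min, 1 min and 6 min (a higher number here means a weaker inhibitor, a lower number a stronger inhibitor), are two compounds:
- compound 1 `CCOC(=O)c1c(C)nc(-c2cccc(C#N)c2)n1OCc1ccncc1` gives 6200 nM in this test
- compound 2 `CCOC(=O)c1c(C)nc(-c2cccc(C#N)c2)n1OCc1ccc(F)cc1` gives 5880 nM in this test

Compound 2 at 5880 nM stands level with compound 1 at 6200 nM within the scatter. Compound 3 `CCOC(=O)c1c(C)nc(-c2cccc(C#N)c2)n1OCc1ccccc1Cl` keeps the shared core and differs from compound 2 in one group. The change is 2-chlorophenyl in place of 4-fluorophenyl on a saturated chain carbon bound to an oxygen on an aromatic ring and it places 2-chlorophenyl where 4-fluorophenyl stood on a saturated chain carbon bound to an oxygen on an aromatic ring. Among the compounds with values here, the only measured step at this place is a 1.1-fold lower number from compound 1 to compound 2 (0.02 log units; within the scatter) and it gives no ground to expect a shift in either direction in this assay beyond the scatter. Within the data shown here, no 2-chlorophenyl compound has yet been measured, so this expectation rests on a single step. The expected change is a 1.1-fold lower number from compound 2 to compound 3 (0.03 log units; within the scatter) and no more than scatter. Compound 3 is estimated at 5500 nM with an expected range from 2000 nM to 15000 nM on this thin evidence.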

Compound 3, half-maximal inhibitory concentration: 8710 nM
Beside the measured number, compound 3's estimate is 1.6-fold (0.20 log units) below it, within the range that was stated.
By their numbers in this assay, from the lowest: compounds 2, 1 and 3 (each within the scatter of the next).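

In this assay, 2-chlorophenyl in place of 4-fluorophenyl gives a 1.5-fold higher number from compound 2 to compound 3 (0.17 log units; within the scatter), and 2-chlorophenyl in place of pyridin-4-yl gives a 1.4-fold higher number from compound 1 to compound 3 (0.15 log units; within the scatter). With a chlorine-bearing ring now in the series, all three aromatic groups at this place, on a saturated chain carbon bound to an oxygen on an aromatic ring, stand level within the scatter, so neither of these new steps separates 2-chlorophenyl from the earlier groups. Nothing available explains why these groups read alike, and no supporting data bear on this result.

Still open, going by these compounds, is whether any group at this place can move the number beyond the scatter, for instance a primary amine or a carboxylic acid on the ring. A longer chain carrying the 2-chlorophenyl group is equally undecided.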